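Trimming the Amide Substituent Down to a Primary Amide

A few compounds are considered here, and "the series" means these few. Any claim that something is new, unique, unknown or untested is made for them only; others in the source may bear on it.

Compound 1 `Cc1occc1-c1nnc(SCC(=O)Nc2cccc(Cl)c2)n1Cc1ccco1`: 63.1 nM
Compound 2 `COc1ccc(NC(=O)CSc2nnc(-c3ccoc3C)n2Cc2ccco2)cc1`: 200 nM
Compound 3 `Cc1occc1-c1nnc(SCC(=O)NN2CCc3ccccc32)n1Cc1ccco1`: 1000 nM

All three were tested in a functional assay on CHO cells for antagonist activity at Orexin receptor type 2 (Homo sapiens), read by FLIPR and calcium flux; on this read-out higher numbers stand for weaker inhibition and lower numbers for stronger inhibition. Compound 3 gives the highest number of the three, and since both a 16-fold higher number from compound 1 to compound 3 (1.20 log units; beyond the scatter) and a 5.0-fold higher number from compound 2 to compound 3 (0.70 log units; beyond the scatter) lie beyond the scatter, it is the weakest inhibitor of this small set. Compound 4 `Cc1occc1-c1nnc(SCC(N)=O)n1Cc1ccco1` differs from compound 3 by hydrogen in place of 2,3-dihydro-1H-indol-1-yl on an amide-type nitrogen. Among the compounds with values here, no measured step removes this group entirely, but the steps that bear on it, a 3.2-fold higher number from compound 1 to compound 2 (0.50 log units; beyond the scatter) and a 5.0-fold higher number from compound 2 to compound 3 (0.70 log units; beyond the scatter), show that what sits on the amide-type nitrogen moves the number by modest to large amounts. Stripping it to bare hydrogen is expected to raise the number further, so compound 4 is estimated at 3000 nM, with a range from 800 nM to 15000 nM. The expected step is a 3.0-fold higher number from compound 3 to compound 4 (0.48 log units; beyond the scatter).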

Compound 4, inhibition constant: > 15800 nM
Compound 4 was reported as a limit; the forecaster's own chance of this, stated with the estimate: 25%; middle value at least 5.2-fold (0.72 log units) away from the limit.
By their numbers in this assay, from the lowest: compound 1; then compound 2; then compound 3. At a limit, above all of these: compound 4.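

Compound 4 is reported only as a limit: the limit of > 15800 nM in this assay, at which 1 of the 4 values shown sits. Even 2,3-dihydro-1H-indol-1-yl, the group giving the highest measured number so far, does far better than bare hydrogen (an at least 15-fold higher number from compound 3 to compound 4 (1.19 log units; beyond the scatter)), and the gaps from 4-methoxyphenyl (an at least 79-fold higher number from compound 2 to compound 4 (1.89 log units; beyond the scatter)) and 3-chlorophenyl (an at least 250-fold higher number from compound 1 to compound 4 (2.39 log units; beyond the scatter)) are wider still. Among these four compounds, then, inhibition depends on having a substituent on this amide-type nitrogen, which the earlier compounds, all carrying one, could not show. Still open, from the compounds shown here alone, is whether a group as short as methyl or ethyl would recover any inhibition. Going by these compounds, the true number for compound 4 also remains unknown.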